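The compounds below may be only part of what the source reports. "The series", "measured", "known", "first", "only" and "open" are said of these compounds alone.

Cytotoxicity notes on the series. Compound 1 `Cc1ccc2cc(CN(Cc3ccc(F)cc3)Cc3ccc(C(C)(C)C)cc3)c(=O)[nH]c2c1` gives only a limit in a toxicity assay on MDCK cells (Canis lupus familiaris) for cytotoxicity, read by crystal violet staining, with a stated time of 48 h (a lower number here means that less compound is tolerated, a higher number that more compound is tolerated), namely > 33000 nM. Compound 2 `CCc1ccc(CN(Cc2ccc(F)cc2)Cc2cc3ccc(C)cc3[nH]c2=O)cc1` likewise reaches only the limit of > 33000 nM. Compound 3 `CC(C)c1ccc2[nH]c(=O)c(CN(Cc3ccc(F)cc3)Cc3ccc(C(C)(C)C)cc3)cc2c1` gives 7900 nM in this assay. On the numbers shown, compound 2 sits at the limit of > 33000 nM in this assay, at which 2 of the 3 values shown sit. Within the data shown here, the single step between measured compounds, a step that the two limits leave unreadable from compound 1 to compound 2, has no readable size. Compound 4 `Cc1ccc2cc(CN(Cc3ccc(F)cc3)C(=O)c3ccccc3)c(=O)[nH]c2c1` carries benzoyl in place of 4-ethylbenzyl on an amine nitrogen. Among the measured compounds shown here, no measured step follows this change on the amine nitrogen, so no measured step gives a guide to its size or direction. Compound 4 is expected to remain at or near the limit, with a step that the limit leaves unreadable from compound 2 to compound 4 estimated as none beyond the scatter. The estimate for compound 4 is 40000 nM, with a range from 15000 nM to 100000 nM.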

Compound 4, half-maximal cytotoxic concentration: > 33000 nM
Compound 4 gave a limit, no number (the forecaster's own chance of this, stated with the estimate: 70%); the middle value does not contradict the limit.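

Compound 4 gives only a limit, as do compound 1 and compound 2, so the steps to compound 4 from both cannot be read: the limit of > 33000 nM in this assay, at which 3 of the 4 values shown sit.

On these data alone, whether benzoyl in place of 4-ethylbenzyl on an amine nitrogen shifts tolerance at all stays open.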